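Furan in Place of Chlorophenyl on a Thiosemicarbazone Scaffold

This account rests on a few compounds, and the source may have more. Where it says the series, first, only, none or still open, it means among the compounds named here.

Compound 1 `CC1=CC[C@H](C(C)(C)NC(=S)N/N=C/c2ccccc2Cl)CC1`: 81000 nM
Compound 2 `CC1=CC[C@H](C(C)(C)NC(=S)N/N=C/c2cccc(Cl)c2)CC1`: 21400 nM

Among the compounds with values here, in a functional assay on NCI-H460 cells (Homo sapiens) for inhibition, read by sulforhodamine B assay, with a stated time of 48 h (a higher number here means a weaker inhibitor of growth, a lower number a stronger inhibitor of growth), compound 2 stands at the lower of the two numbers; its only neighbour, compound 1, gives 81000 nM, and a 3.8-fold lower number from compound 1 to compound 2 (0.58 log units; beyond the scatter). Compound 3 `CC1=CC[C@H](C(C)(C)NC(=S)N/N=C/c2ccco2)CC1` differs from compound 2 by furan-2-yl in place of 3-chlorophenyl on a carbon with a double bond to nitrogen. Within the data shown here, no measured step exchanges the aromatic ring itself; the single measured step merely moves a chlorine, so its size is the only yardstick, and the direction of a ring swap is not known from these data. For compound 3 the number is expected to shift by a 1.9-fold higher number from compound 2 to compound 3 (0.27 log units; within the scatter), and compound 3 is estimated at 40000 nM (range 12000 nM to 130000 nM).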

Compound 3, concentration for total growth inhibition: 10800 nM
For compound 3 the middle estimate is 3.7-fold (0.57 log units) above the measured one; measured number below the stated range.
By their numbers in this assay, from the lowest: compounds 3 and 2 (each within the scatter of the next); then compound 1.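

Swapping the aromatic ring itself at this carbon with a double bond to nitrogen gives a 2.0-fold lower number from compound 2 to compound 3 (0.30 log units; within the scatter) in this assay, so furan-2-yl and 3-chlorophenyl cannot be told apart here. Furan-2-yl in place of 2-chlorophenyl gives a 7.5-fold lower number from compound 1 to compound 3 (0.88 log units; beyond the scatter), so the same entering ring produces a clear difference only against that chlorophenyl group. No evidence is available to explain these numbers.

Still open, on these data alone, is whether a pyridine ring, a thiophene ring or an unsubstituted phenyl ring would fit with these results. As far as these compounds go, whether a methoxy group or a bromine on the furan ring would change the number also remains unknown.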